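A few compounds are considered here, and "the series" means these few. Any claim that something is new, unique, unknown or untested is made for them only; others in the source may bear on it.

Measured in an ADME assay for permeability, using PAMPA; a lower number here means that the compound crosses the layer more slowly, a higher number that the compound crosses the layer faster:
compound 1 `NCCNC(=O)/C=N/O` — compound 1 gives 1.4 10^-6 cm/s
compound 2 `C[N+](C)(C)CCNC(=O)/C=N/O` — compound 2 gives 1.6 10^-6 cm/s
compound 3 `O=C(/C=N/O)NCc1ncc[nH]1` — compound 3 gives 1.1 10^-6 cm/s

Standing of compound 2: all three numbers lie close together. Compound 1 and compound 3 are each within the scatter of compound 2, so no order among the three can be read from these values. Going by the values given here, the one step that bears on the present change is a 1.1-fold higher number from compound 1 to compound 2 (0.06 log units; within the scatter), and it stayed within the scatter.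

Compound 4 `CN(C)CCCNC(=O)/C=N/O` has not yet been run in this assay. The change from compound 2 is a group of 4 heavy atoms (3 carbon, 1 nitrogen; no ring) in place of a group of 4 heavy atoms (3 carbon, 1 nitrogen; no ring), on a saturated chain carbon, two bonds along the chain from an amide-type nitrogen. Among the compounds with values here, the group that leaves is the one that entered from compound 1 to compound 2, and that exchange moved the number by an amount inside the scatter. Within the data shown here, nothing measured so far speaks for a step beyond the scatter here, so the expectation for the step from compound 2 to compound 4 is a 1.1-fold higher number from compound 2 to compound 4 (0.05 log units; within the scatter), small and not distinguishable from repeat measurement. For compound 4 the estimated value is 1.8 10^-6 cm/s, with a range from 0.9 10^-6 cm/s to 3.6 10^-6 cm/s.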

Compound 4, apparent permeability: 1.8 10^-6 cm/s
The estimate for compound 4 equals the measured number at the digits printed, within the range that was stated.
By their numbers in this assay, from the lowest: compounds 3, 1, 2 and 4 (each within the scatter of the next).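

In this assay, (dimethylamino)methyl, with no net charge, in place of the group with net charge +1 gives a small step (a 1.1-fold higher number from compound 2 to compound 4 (0.05 log units; within the scatter)), and (dimethylamino)methyl in place of amino also stays small (a 1.3-fold higher number from compound 1 to compound 4 (0.11 log units; within the scatter)). Groups with and without a net charge, on a saturated chain carbon, two bonds along the chain from an amide-type nitrogen, now stand within the scatter of each other, which the single earlier step from amino to the charged group could not show. No measurement at hand offers an explanation for this flat reading.

Going by these compounds alone, every step at this place so far lies within the scatter, so the range of groups tolerated there without a larger step remains undefined. As far as these compounds go, whether a carboxylic acid, a phenyl group or a longer chain would give a step beyond the scatter remains open.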